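Thiourea and urea nucleoside analogues: cytotoxicity notes

This account rests on a few compounds, and the source may have more. Where it says the series, first, only, none or still open, it means among the compounds named here.

Measured so far in an ADME assay on MRC5 cells (Homo sapiens) for cytotoxicity; on this read-out lower numbers stand for higher toxicity in this test and higher numbers for lower toxicity in this test:
- compound 1 `COc1ccc(NC(=O)NC[C@H]2O[C@H](n3cc(C)c(=O)[nH]c3=O)C[C@@H]2O)cc1`: > 50000 nM, a limit of the assay, not a number.
- compound 2 `Cc1cn([C@@H]2C[C@H](O)[C@@H](CNC(=O)Nc3ccc(Cl)c(C(F)(F)F)c3)O2)c(=O)[nH]c1=O`: > 50000 nM, again a limit.
- compound 3 `Cc1cn([C@@H]2C[C@H](O)[C@@H](CNC(=S)Nc3ccc(OCc4ccccc4)cc3)O2)c(=O)[nH]c1=O`: > 50000 nM, again a limit.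

Compound 1 therefore stands where every measured member of the series stands: at the limit of > 50000 nM in this assay, at which 3 of the 3 values shown sit. Among the compounds with values here, no measured value lies away from that limit, so no step between measured compounds can be read from the numbers, and nothing distinguishes compound 1 from compound 2 or compound 3 on this read-out.

Compound 4 `Cc1cn([C@@H]2C[C@H](O)[C@@H](CNC(=O)Nc3ccc(Cc4ccccc4)cc3)O2)c(=O)[nH]c1=O` has not yet been measured in this assay. It differs from compound 1 by benzyl in place of methoxy on an aromatic carbon. Within the data shown here, with all three measured compounds sitting at the same limit, there is no measured step that would point to a change in either direction, and the expected step of a number no higher from compound 1 to compound 4 (the limit leaves the size open) is none beyond the scatter. For compound 4 the estimated value in this assay is 50000 nM, within 20000 nM to 100000 nM, most likely reported again only as a limit.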

Compound 4, half-maximal cytotoxic concentration: > 50000 nM
Compound 4 ended at the assay's limit; the forecaster's own chance of this, stated with the estimate: 80%; the middle value sits exactly at the limit.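

In this assay compound 4 gives > 50000 nM, a limit of the assay and not a number. No step from compound 1 to compound 4 can be read, because both sit at the same limit: the limit of > 50000 nM in this assay, at which 4 of the 4 values shown sit.

The compounds shown leave open whether benzyl in place of methoxy changes cytotoxicity at all, and where any of them would give a measurable value in this assay.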